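This account rests on a few compounds, and the source may have more. Where it says the series, first, only, none or still open, it means among the compounds named here.

Measured compounds:
Compound 1 `COc1ncc(-c2ccccc2)cc1[C@@H](c1ccccc1)[C@@](O)(CCN(C)C)c1ccccc1` gives a limit, > 50 ug/mL, in this assay.
Compound 2 `COc1nc(-c2cccc(F)c2)ccc1[C@@H](c1ccccc1)[C@@](O)(CCN(C)C)c1cccc2ccccc12` likewise gives only a limit, > 50 ug/mL.

Both readings come from a toxicity assay on Vero cells (Chlorocebus sabaeus) for cytotoxicity; a lower number here means that less compound is tolerated, a higher number that more compound is tolerated. Neither is a number: each is the limit of the assay, and both sit at the limit of > 50 ug/mL in this assay, at which 2 of the 2 values shown sit. So compound 2 stands where every value shown stands, at the upper edge of what the assay can report, and nothing separates it from compound 1.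

Compound 3 `COc1nc(-c2ccc(C(F)(F)F)cc2)ccc1[C@@H](c1ccccc1)[C@@](O)(CCN(C)C)c1cccc2ccccc12` has not been measured. It differs from compound 2 in one place: 4-(trifluoromethyl)phenyl in place of 3-fluorophenyl on an aromatic carbon. Going by the values given here, no measured pair shows how a change of this kind moves this assay, so the size of the step is unknown. The expectation is that the step of a number no higher from compound 2 to compound 3 (the limit leaves the size open) stays within the usual scatter, with compound 3 again tolerated up to the limit. Compound 3 is therefore estimated at 50 ug/mL, within 20 ug/mL to 100 ug/mL.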

Compound 3, half-maximal cytotoxic concentration: > 50 ug/mL
Compound 3: only a limit was reported (the forecaster's own chance of this, stated with the estimate: 70%); the middle value lies on the limit itself.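

Compound 2 and compound 3 both give only a limit in this assay, so no step can be read between them: the limit of > 50 ug/mL in this assay, at which 3 of the 3 values shown sit.

Still open is what concentration harms the cells for any of these compounds, and whether 4-(trifluoromethyl)phenyl in place of 3-fluorophenyl changes it at all.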